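The source may hold more compounds than are shown below. What is called first, only, known or untested is meant among the compounds shown, and "the series" means these compounds.

Compound 1 `O=C(/C=C/c1cccc(O)c1)CC(=O)/C=C/c1cccc(O)c1O` and compound 2 `O=C(/C=C/c1cc(O)ccc1O)CC(=O)/C=C/c1cccc(O)c1O` share one core and differ only in that (hydroxy in place of hydrogen on an aromatic carbon). In an ADME assay on PC-12 cells (Rattus norvegicus) for cytotoxicity, read by WST assay, with a stated time of 24 h (a higher number here means that more compound is tolerated, a lower number that less compound is tolerated), compound 1 gives 38000 nM, and compound 2 gives 53000 nM; this step is a 1.4-fold higher number from compound 1 to compound 2 (0.14 log units; within the scatter). Compound 3 `O=C(/C=C/c1cccc(O)c1)/C=C/c1ccc(O)c(O)c1` is built on another core, and the difference between the two cores is not broken down here. In this assay compound 3 gives only a limit, > 100000 nM. The assay there reports (the limit of > 100000 nM in this assay, at which 1 of the 3 values shown sits). Compound 4 `O=C(/C=C/c1ccc(O)c(O)c1)/C=C/c1cc(O)ccc1O` differs from compound 3 by the same change, (hydroxy in place of hydrogen on an aromatic carbon). Because the measured step of a 1.4-fold higher number from compound 1 to compound 2 (0.14 log units; within the scatter) stays within the scatter, the step to compound 4 is expected to be small as well, a step that the limit leaves unreadable from compound 3 to compound 4. Compound 4 is therefore estimated at 120000 nM in this assay, most likely again reported only as a limit.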

Compound 4, half-maximal cytotoxic concentration: 39000 nM
The estimate for compound 4 lay 3.1-fold (0.49 log units) above the measured number, and the stated range ends above it.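

Put on the core of compound 3, hydroxy in place of hydrogen gives an at least 2.5-fold lower number from compound 3 to compound 4 (0.40 log units; beyond the scatter) and so does not carry over at the same size from the core of compound 1: the same change on two cores in this assay, a 1.4-fold higher number (0.14 log units; within the scatter) from compound 1 to compound 2 and an at least 2.5-fold lower number (0.40 log units; beyond the scatter) from compound 3 to compound 4, at least 3.5-fold (0.55 log units) apart, beyond the scatter of two such steps. Compound 3 gives > 100000 nM in this assay as a limit and not a number, so only the smallest possible size of its step is known. With just two pairs of compounds, this shows that the step on one of these cores cannot be assumed on the other, but it does not show why the two differ or what would happen on a third core.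

Still open, going by these compounds, is whether hydroxy at other places on these rings would show the same gap between the cores. On these data alone, it is also open whether another group in this place, such as an amine or a carboxylic acid, would differ between them.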